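Dihydroxy-diiodophenyl hydrazides: halogen swap on the chlorophenyl arm

The source may hold more compounds than are shown below. What is called first, only, known or untested is meant among the compounds shown, and "the series" means these compounds.

Measured compounds:
compound 1 `O=C(N/N=C/c1cc(I)c(O)c(I)c1)c1ccc(Cl)cc1`, > 100000 nM
compound 2 `O=C(N/N=C/c1cc(I)c(O)c(I)c1)c1ccc(Br)cc1`, > 50000 nM
compound 3 `O=C(NNC(=O)c1cc(I)cc(I)c1O)c1ccc(Cl)cc1`, 48700 nM

In a functional assay on HepG2 cells (Homo sapiens) for cytotoxicity, with a stated time of 24 h (a higher number here means a weaker inhibitor, a lower number a stronger inhibitor), compound 1 gives only a limit, > 100000 nM, at the limit of > 100000 nM in this assay, at which 1 of the 3 values shown sits. Compound 2 likewise gives only a limit in this assay, > 50000 nM, at the limit of > 50000 nM in this assay, at which 1 of the 3 values shown sits. Compound 1 and compound 2 differ by bromo in place of chloro on an aromatic carbon, but a step that the two limits leave unreadable from compound 1 to compound 2, so the size of that step is not readable. Compound 3 is the only one of the three with a number in this assay, 48700 nM; how its core differs from that of compound 1 is not broken down here.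

Compound 4 `O=C(NNC(=O)c1cc(I)cc(I)c1O)c1ccc(Br)cc1` is not yet measured and differs from compound 3 by bromo in place of chloro on an aromatic carbon, the same change as between compound 1 and compound 2. The expected step of a 1.1-fold higher number from compound 3 to compound 4 (0.05 log units; within the scatter) is small, resting on compound 3 at 48700 nM. Compound 1 and compound 2, with the step between them unreadable, give no sign of a large effect of the halogen swap. Compound 4 is therefore estimated at 55000 nM, between 20000 nM and 130000 nM, with a fair chance that this assay reports only a limit.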

Compound 4, half-maximal inhibitory concentration: 62800 nM
Beside the measured number, compound 4's estimate is 1.1-fold (0.06 log units) below it, within the range that was stated.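

In this assay, bromo in place of chloro on the core of compound 3 gives a 1.3-fold higher number from compound 3 to compound 4 (0.11 log units; within the scatter) and so leaves the number essentially unmoved on this core. On the core of compound 1 the same change cannot be read, as compound 1 and compound 2 each give only a limit. The result therefore rests on one core and does not show that the change carries from one core to the other, and no measured property bears on it.

As far as these compounds go, whether an amine or a carboxylic acid in place of the halogen would move the number in this assay beyond the scatter stays open on both cores. From the compounds shown here alone, the effect of the core itself also stays open, with compound 1 giving only a limit.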